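Carbonyl substituent variation and maximal response

The source may report more compounds than this note shows. Statements on the series, on what has been measured and on what is new or still open speak of the compounds shown alone.

Measured so far:
compound 1 `Cc1nc(S(C)(=O)=O)ccc1Oc1ncnc(OC2CCN(C(=O)OC3CCC3)CC2)c1F` — 81%
compound 2 `Cc1nc(S(C)(=O)=O)ccc1Oc1ncnc(OC2CCN(C(=O)OC(C)(C)C(F)(F)F)CC2)c1F` — 79%
compound 3 `Cc1nc(S(C)(=O)=O)ccc1Oc1ncnc(OC2CCN(C(=O)SC3(C)CC3)CC2)c1F` — 77%

The three compounds share one core and differ only in the group on a carbonyl carbon whose other neighbours are an amide-type nitrogen in a ring. In a functional assay on isolated protein for inhibition of Glucose-dependent insulinotropic receptor (Rattus norvegicus), read by HTRF and cAMP accumulation (on this read-out lower numbers stand for smaller maximal responses and higher numbers for larger maximal responses), the steps between them are small: a number 2 percentage points lower from compound 1 to compound 2 (within the scatter), a number 4 percentage points lower from compound 1 to compound 3 (within the scatter) and a number 2 percentage points lower from compound 2 to compound 3 (within the scatter). Compound 3 therefore sits within the scatter of both compound 1 and compound 2, and no ordering among the three can be claimed.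

Compound 4 `Cc1nc(S(C)(=O)=O)ccc1Oc1ncnc(OC2CCN(C(=O)C(C)(C)F)CC2)c1F` is the next member. Change from compound 3: a group of 4 heavy atoms (3 carbon, 1 fluorine; no ring) in place of a group of 5 heavy atoms (4 carbon, 1 sulfur; one three-membered non-aromatic ring of carbon only), on a carbonyl carbon. Among the measured compounds shown here, the steps that bear on this are the two that also replace the group on the carbonyl carbon, a number 4 percentage points lower from compound 1 to compound 3 (within the scatter) and a number 2 percentage points lower from compound 2 to compound 3 (within the scatter), neither beyond the scatter; the change from compound 1 to compound 2 alters the same position and is likewise within the scatter, a number 2 percentage points lower from compound 1 to compound 2 (within the scatter). For the measured compounds named here, no measured compound carries a group of the kind entering here, so the expectation rests on the tolerance seen so far. Compound 4 is expected to show no step beyond the scatter, a number 1 percentage points higher from compound 3 to compound 4 (within the scatter). The estimate for compound 4 is 78%, with a range from 66% to 90%.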

Compound 4, largest response reached (reported as efficacy), in percent of the reference or control that the assay uses: 74%
Compound 4: the middle estimate sits 4 percentage points above what was measured; the range from low to high includes it.
By their numbers in this assay, from the lowest: compounds 4, 3, 2 and 1 (each within the scatter of the next).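

In this assay, the 1-fluoro-1-methylethyl group on the carbonyl carbon gives a number 3 percentage points lower from compound 3 to compound 4 (within the scatter) and a number 5 percentage points lower from compound 2 to compound 4 (within the scatter) and a number 7 percentage points lower from compound 1 to compound 4 (within the scatter) in this series. The earlier compounds shown here all carried a group joined to the carbonyl carbon through oxygen or sulfur, whereas here a group joined through carbon also keeps the maximal response within the scatter of all three. No supporting measurement explains this tolerance.

Open is whether a dimethylamino group or a longer alkyl chain on the carbonyl carbon would also stay within the scatter of these compounds. Also open, going by these compounds, is what the fluorine of 1-fluoro-1-methylethyl contributes, a question that a direct pair with an isopropyl group would settle.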